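The source may report more compounds than this note shows. Statements on the series, on what has been measured and on what is new or still open speak of the compounds shown alone.

The measured compounds:

Compound 1, `[N-]=[N+]=NCc1ncnc2c1ncn2[C@@H]1O[C@H](CO)[C@@H](O)[C@H]1O`: in a functional assay on Huh-7 cells (Homo sapiens) for cytotoxicity, read by MTT assay, with a stated time of 3 days (a higher number here means that more compound is tolerated, a lower number that less compound is tolerated), compound 1 gives > 250000 nM, which is a limit of the assay and not a number.
Compound 2, `OC[C@H]1O[C@@H](n2cnc3c(CSc4ccccn4)ncnc32)[C@H](O)[C@@H]1O`: in this assay compound 2 gives > 100000 nM, again a limit of the assay and not a number.
Compound 3, `O=C1CCCN1Cc1ncnc2c1ncn2[C@@H]1O[C@H](CO)[C@@H](O)[C@H]1O`: in this assay compound 3 gives 45000 nM.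

Compound 2 therefore stands only at a limit, and of the other two values one is a limit as well. The step from compound 1 to compound 2 is a step that the two limits leave unreadable from compound 1 to compound 2. Among the measured compounds shown here, the one readable step from compound 2 is an at least 2.2-fold lower number from compound 2 to compound 3 (0.34 log units; beyond the scatter), and the corresponding step from compound 1 is an at least 5.5-fold lower number from compound 1 to compound 3 (0.74 log units; beyond the scatter); both show that the 2-oxopyrrolidin-1-yl compound is tolerated less than the two others.

Compound 4, `OC[C@H]1O[C@@H](n2cnc3c(CSc4nc5ccccc5s4)ncnc32)[C@H](O)[C@@H]1O`, carries the change (1,3-benzothiazol-2-yl in place of pyridin-2-yl on a sulfur). For the measured compounds named here, no measured step varies the group on the sulfur, so the bearing of the known steps is weak; they only show that compound 2 itself sits at the tolerant end of what has been seen. A larger group on the sulfur is expected to lower the tolerated concentration somewhat, though the expected step of an at least 1.2-fold lower number from compound 2 to compound 4 (0.09 log units; that floor lies within the scatter) in this assay stays near the scatter. Compound 4 is therefore expected to give about 80000 nM, with a range from 25000 nM to 250000 nM.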

Compound 4, half-maximal cytotoxic concentration: > 100000 nM
Compound 4 ended at the assay's limit (the forecaster's own chance of this, stated with the estimate: 45%); middle value at least 1.2-fold (0.09 log units) from the limit.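

In this assay compound 4 gives > 100000 nM, a limit of the assay and not a number. Compound 2 stands at that same limit, so no step from compound 2 to compound 4 can be read: the limit of > 100000 nM in this assay, at which 2 of the 4 values shown sit.

The compounds shown leave open whether 1,3-benzothiazol-2-yl in place of pyridin-2-yl on a sulfur changes the tolerated concentration in this assay at all.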